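The source may hold more compounds than are shown below. What is called first, only, known or untested is meant among the compounds shown, and "the series" means these compounds.

The study compares thiosemicarbazones built on one shared core, measured in a functional assay on MCF7 cells (Homo sapiens) for cytotoxicity, read by MTT assay, with a stated time of 72 h, tested at 1 uM; a lower number here means less inhibition of growth, a higher number more inhibition of growth at the concentration tested. Compound 1 `N/C(=N\NC(=S)N1CCCCCC1)c1ccccn1` gives 25.3%. Compound 2 `N/C(=N\NC(=S)N1CCOCC1)c1ccccn1` gives 14.7%, which places compound 2 second highest of the three numbers, the number of compound 1 standing higher by more than the scatter and that of compound 3 standing lower by more than the scatter. Going by the values given here, compound 3 `Cc1ccnc(/C(N)=N/NC(=S)N2CCOCC2)c1` gives 1.22%, and the single step that differs in one place, methyl in place of hydrogen on an aromatic carbon, is a number 13.5 percentage points lower from compound 2 to compound 3 (beyond the scatter).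

Compound 4 `N/C(=N\NC(=S)N1CCCCC1)c1ccccn1` has not yet been measured. It differs from compound 2 by piperidin-1-yl in place of morpholin-4-yl on a thiocarbonyl carbon. Among the compounds with values here, no measured step changes this ring alone: compound 1 and compound 2 differ in both ring size and ring composition, so only their two values can be read side by side, and the methyl step from compound 2 to compound 3 concerns another part of the molecule. On that footing only a modest step upward is expected in this assay, because the values of compound 1 25.3% and compound 2 14.7% bracket the change. Compound 4 is therefore estimated at 20%, within 6% to 34%, an expected step of a number 5.3 percentage points higher from compound 2 to compound 4 (within the scatter).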

Compound 4, percent growth inhibition at one concentration: 15.4%
Estimate against measurement, compound 4: 4.6 percentage points above; the range from low to high includes it.
By their numbers in this assay, from the lowest: compound 3; then compounds 2, 4 and 1 (each within the scatter of the next, the first and the last beyond it).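

In this assay, piperidin-1-yl in place of morpholin-4-yl on a thiocarbonyl carbon gives a number 0.7 percentage points higher from compound 2 to compound 4 (within the scatter), so with the six-membered ring kept, this exchange leaves no difference that can be told from the scatter. The earlier compounds shown here offered only compound 1 at 25.3% and compound 2 at 14.7%, a pair that differs in both ring size and ring composition, whereas this step isolates the exchange of one ring for the other at equal size, and compound 4 stands within the scatter of both compound 2 and compound 1. No accompanying measurement bears on this result.

The compounds shown leave open whether an open-chain amine such as diethylamino on the thiocarbonyl carbon would also stay within the scatter of compound 2. They also leave open whether methyl in place of hydrogen on an aromatic carbon, which gave a number 13.5 percentage points lower from compound 2 to compound 3 (beyond the scatter), would bring a similar step when piperidin-1-yl rather than morpholin-4-yl sits on the thiocarbonyl carbon.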